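Replacing the fluorobenzyl arm of compound 1 with phenyl

The compounds below may be only part of what the source reports. "The series", "measured", "known", "first", "only" and "open" are said of these compounds alone.

Compound 1 `CCOC(=O)c1ccc(-c2nn(Cc3cccc(F)c3)c3ccccc23)cc1` gives 270 nM in a functional assay on cells (Platelet, Homo sapiens) for inhibition; a higher number here means a weaker inhibitor, a lower number a stronger inhibitor.
Compound 2 `CCOC(=O)c1cccc(-c2nn(Cc3ccccc3)c3ccccc23)c1` reaches only a limit, > 10000 nM, in this assay.
Compound 3 `CCCNC(=O)c1ccc(-c2nn(Cc3ccccc3)c3ccccc23)cc1` likewise reaches only a limit, > 10000 nM, in this assay.

Compound 1 therefore stands alone with a number; the other two results sit at the limit of > 10000 nM in this assay, at which 2 of the 3 values shown sit. Compound 4 `CCOC(=O)c1ccc(-c2nn(-c3ccccc3)c3ccccc23)cc1` differs from compound 1 in one place: phenyl in place of 3-fluorobenzyl on an aromatic nitrogen. For the measured compounds named here, no measured pair mirrors this change, so its size is uncertain. The expected step of a 5.6-fold higher number from compound 1 to compound 4 (0.74 log units; beyond the scatter) points toward weaker inhibition, probably beyond the usual scatter, since the benzylic link present in compound 1 is removed. Compound 4 is estimated at 1500 nM, with a range from 300 nM to 8000 nM.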

Compound 4, half-maximal inhibitory concentration: 2640 nM
Compound 4: middle estimate off by 1.8-fold (0.25 log units), on the low side; low and high end bracket the measured number.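

Phenyl in place of 3-fluorobenzyl on the aromatic nitrogen gives a 9.8-fold higher number from compound 1 to compound 4 (0.99 log units; beyond the scatter) in this assay, which is the first readable step at this position and points to weaker inhibition. Even so, compound 4 keeps a measurable value and does not join the compounds that reach only a limit: the limit of > 10000 nM in this assay, at which 2 of the 4 values shown sit.

The change removes the fluorine and the benzylic link together, so the compounds shown cannot say which of the two accounts for the step. From the compounds shown here alone, how a longer chain or an amine on this nitrogen would read also stays open.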